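A few compounds are considered here, and "the series" means these few. Any claim that something is new, unique, unknown or untested is made for them only; others in the source may bear on it.

Measured so far in a functional assay on DU-145 cells (Homo sapiens) for cytotoxicity, read by MTT assay, with a stated time of 48 h; on this read-out lower numbers stand for stronger inhibition and higher numbers for weaker inhibition:

Compound 1 `COc1cc(-c2cc(COCc3cn(Cc4cc(C)cnc4Cl)nn3)on2)cc(OC)c1OC`: 39800 nM
Compound 2 `COc1cc(C2=NOC(COCc3cn(Cc4cc(C)cnc4Cl)nn3)C2)cc(OC)c1OC`: 58900 nM

Compound 2 at 58900 nM and compound 1 at 39800 nM lie within the scatter of each other, so these two numbers cannot be told apart. Going by the values given here, compound 2 therefore stands level with the only other measured compound, and both sit in the same weak range of this assay.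

Compound 3 `COc1cc(C2=NOC(COCc3cn(Cc4cc(-c5ccc(C)cc5)cnc4Cl)nn3)C2)cc(OC)c1OC` keeps the core of compound 2 and carries 4-methylphenyl in place of methyl on an aromatic carbon, para to the chloro group: 4-methylphenyl in place of methyl on an aromatic carbon. Among the compounds with values here, no two measured compounds differ in one place, so the data hold no direct measure of what a change at this carbon does. The expectation therefore rests on the structural change alone, and it is a cautious one: a modest move toward stronger inhibition, with no change beyond the scatter remaining quite possible. The expected change is a 2.1-fold lower number from compound 2 to compound 3 (0.32 log units; beyond the scatter). Compound 3 is estimated at 28000 nM, with an expected range of 8000 nM to 70000 nM.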

Compound 3, half-maximal inhibitory concentration: 13100 nM
Beside the measured number, compound 3's estimate is 2.1-fold (0.33 log units) above it; the measured number falls inside the stated range.
By their numbers in this assay, from the lowest: compound 3; then compounds 1 and 2 (each within the scatter of the next).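

In this assay, replacing methyl with 4-methylphenyl on the aromatic carbon para to the chloro group gives a 4.5-fold lower number from compound 2 to compound 3 (0.65 log units; beyond the scatter), the first direct measure of a change at this carbon, and it shows that the read-out responds to what sits there. The carbon accepts a substituent of 7 heavy atoms, including a six-membered aromatic ring of carbon only, in place of a single carbon, and the number moves toward stronger inhibition rather than weaker, though the step remains modest. Nothing measured here accounts for the shift, so its cause remains unknown.

A single step cannot separate the contribution of the added aromatic ring from that of its methyl group, a question that phenyl or 4-methoxyphenyl at this carbon would address, while an amine or a carboxylic acid there would test how far the response extends beyond aromatic carbon substituents. The compounds shown also leave open whether 4-methylphenyl would produce a similar step on the core of compound 1.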